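From a bromo to a methoxy group: compound 2 to compound 3

A few compounds are considered here, and "the series" means these few. Any claim that something is new, unique, unknown or untested is made for them only; others in the source may bear on it.

Compound 2 `O=[N+]([O-])c1ccc(CN2CCC(n3cc(CC(OCc4cc(-c5cccc(Br)c5)no4)c4ccc(Br)cc4)nn3)CC2)cc1` carries a 3-bromophenyl group. In a functional assay on PC-3 cells (Homo sapiens) for cytotoxicity, with a stated time of 48 h (a higher number here means a weaker inhibitor, a lower number a stronger inhibitor), compound 2 gives > 25000 nM, which is a limit of the assay rather than a number. Its close relative compound 1 `N#Cc1ccc(-c2cc(COC(Cc3cn(C4CCN(Cc5ccc([N+](=O)[O-])cc5)CC4)nn3)c3ccc(Br)cc3)on2)cc1` has a 4-cyanophenyl group in the same place, and in this assay compound 1 gives 2000 nM. The step of an at least 12-fold higher number from compound 1 to compound 2 (1.09 log units; beyond the scatter) shows that this part of the molecule matters, though its full size can only be bounded because of the limit of > 25000 nM in this assay, at which 1 of the 2 values shown sits.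

Compound 3 `COc1cccc(-c2cc(COC(Cc3cn(C4CCN(Cc5ccc([N+](=O)[O-])cc5)CC4)nn3)c3ccc(Br)cc3)on2)c1` differs from compound 2 by methoxy in place of bromo on an aromatic carbon. Among the compounds with values here, no measured step compares a bromo with a methoxy group, so the single step from compound 1 to compound 2 is only a rough guide: it shows that changing the group on this ring can shift the result a great deal, and for all that is known the shift could go either way here. Compound 3 is expected to move toward a measurable number but stay weak, with the expected step of an at least 1.6-fold lower number from compound 2 to compound 3 (0.22 log units; that floor lies within the scatter). Compound 3 is estimated at 15000 nM in this assay, within 3000 nM to 50000 nM.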

Compound 3, half-maximal inhibitory concentration: > 25000 nM
Compound 3 ended at the assay's limit; the forecaster's own chance of this, stated with the estimate: 45%; at least 1.6-fold (0.22 log units) between middle value and limit.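

Replacing the 4-cyanophenyl group with 3-methoxyphenyl gives an at least 12-fold higher number from compound 1 to compound 3 (1.09 log units; beyond the scatter) in this assay. The large loss seen with the 3-bromophenyl group is therefore not confined to bromo, since a second, quite different group on this ring also leaves the compound far weaker than the 4-cyanophenyl compound. The results for compound 2 and compound 3 are both limits of the assay rather than numbers, so the step between them cannot be read and bromo and methoxy cannot be ranked against each other: the limit of > 25000 nM in this assay, at which 2 of the 3 values shown sit.

Going from 4-cyanophenyl to either of these groups changes both the group itself and where it sits on the phenyl ring, so the compounds shown do not separate the nitrile from its place on the ring. Going by these compounds, a 3-cyanophenyl group would address the place of the nitrile, while a 4-methoxyphenyl group would test whether methoxy can do as well as nitrile in that same place, and it remains open whether any other group, such as an amine or a carboxylic acid, would keep measurable activity.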